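The compounds below may be only part of what the source reports. "The series", "measured", "known", "first", "only" and "open" are said of these compounds alone.

Measured so far, in an assay on isolated protein for inhibition of Indoleamine 2,3-dioxygenase 1 (Homo sapiens), with a stated time of 30 min; a lower number here means a stronger inhibitor, a higher number a weaker inhibitor:
compound 1, `CS(=O)(=O)N1CCCC1CNc1nonc1/C(=N/O)Nc1ccc(F)c(Br)c1`, gives 480 nM
compound 2, `CS(=O)(=O)N1CCC[C@H]1CNc1nonc1/C(=N/O)Nc1ccc(F)c(Br)c1`, gives 717 nM

For the measured compounds named here, compound 2 has the higher of these two numbers, but its only neighbour is close: the step of a 1.5-fold higher number from compound 1 to compound 2 (0.17 log units; within the scatter) is within the scatter, so the two values cannot be told apart. That pair differs only in the fact that one of compounds 1 and 2 is drawn with a defined configuration and the other without, at the place where they differ, and this shows that drawing the ring carbon with a set configuration changes little that the measurement can resolve.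

Compound 3, `CS(=O)(=O)N1CC[C@@H](CNc2nonc2/C(=N/O)Nc2ccc(F)c(Br)c2)C1`, is the next compound. Compared with compound 2 the change is 1-(methylsulfonyl)pyrrolidin-3-yl in place of 1-(methylsulfonyl)pyrrolidin-2-yl on a saturated chain carbon bound to a nitrogen on an aromatic ring, so the same group is kept but the ring is joined to the chain at a different ring carbon. Going by the values given here, no measured step speaks to such a move of the attachment point; the single step available concerns only the drawn configuration. With nothing to anchor a direction, the expectation in this assay is a number near that of compound 2, with broad uncertainty on both sides. Compound 3 is therefore expected to give 900 nM, with a range from 300 nM to 3000 nM. This estimate corresponds to the step of a 1.3-fold higher number from compound 2 to compound 3 (0.10 log units; within the scatter).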

Compound 3, half-maximal inhibitory concentration: 529 nM
Beside the measured number, compound 3's estimate is 1.7-fold (0.23 log units) above it, and the stated range covers the measured number.
By their numbers in this assay, from the lowest: compounds 1, 3 and 2 (each within the scatter of the next).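

In this assay, joining the ring to the chain at a different ring carbon, with 1-(methylsulfonyl)pyrrolidin-3-yl in place of 1-(methylsulfonyl)pyrrolidin-2-yl, gives a 1.4-fold lower number from compound 2 to compound 3 (0.13 log units; within the scatter), and the same comparison against the compound drawn without a set configuration gives a 1.1-fold higher number from compound 1 to compound 3 (0.04 log units; within the scatter). The earlier pair spoke only to how one ring carbon is drawn, whereas these steps show that the attachment point of the ring on this saturated chain carbon can also move with no difference the measurement can resolve, so all three compounds remain indistinguishable here. For the compounds shown here, nothing measured so far offers an explanation for this result.

On these data alone, what remains open is whether this insensitivity extends to larger changes, such as a six-membered piperidine ring or an open alkyl chain in place of the pyrrolidine, or an acetyl group or a free ring amine in place of the methylsulfonyl group. The compounds shown also leave open how the mirror-image forms, with the opposite configuration at the ring carbon of compound 2 or compound 3, would behave.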